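The compounds below may be only part of what the source reports. "The series", "measured", "known", "first", "only" and "open" are said of these compounds alone.

Measured in a functional assay on B16 cells (Mus musculus) for cytotoxicity, read by MTT assay, with a stated time of 48 h; a higher number here means a weaker inhibitor, a lower number a stronger inhibitor:
compound 1 `COc1cccc(Cn2cc(-c3ccc(OC)c(OC)c3OC)nn2)c1`, > 100000 nM
compound 2 `CCOC(=O)Cn1cc(-c2ccc3ccccc3c2)nn1`, > 100000 nM

Compound 1 gives only a limit in this assay, > 100000 nM. Compound 2 likewise gives only a limit in this assay, > 100000 nM. Within the data shown here, both results sit at the limit of > 100000 nM in this assay, at which 2 of the 2 values shown sit, so no step between measured compounds exists and compound 1 can be placed only at that limit. Compound 3 `CCOC(=O)Cn1cc(-c2ccc(OC)c(OC)c2OC)nn1` differs from compound 1 by ethoxycarbonyl in place of 3-methoxyphenyl on a saturated chain carbon bound to an aromatic nitrogen. The expected step that the limit leaves unreadable from compound 1 to compound 3 is none beyond the scatter, since two limits give no direction to read. Compound 3 is estimated at 150000 nM, within 50000 nM to 500000 nM, most likely reported again only as a limit.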

Compound 3, half-maximal inhibitory concentration: > 100000 nM
Compound 3 was reported as a limit; the forecaster's own chance of this, stated with the estimate: 85%; the middle value lies beyond the limit too.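

No step can be read from compound 1 to compound 3, because both results are limits: the limit of > 100000 nM in this assay, at which 3 of the 3 values shown sit.

The compounds shown leave open how ethoxycarbonyl and 3-methoxyphenyl compare in this assay, where no measured number is available for either.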